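Notes on a cyano to carbamoyl change

A few compounds are considered here, and "the series" means these few. Any claim that something is new, unique, unknown or untested is made for them only; others in the source may bear on it.

compound 1 `COc1ccc([C@@H]2C/C(=N/OCc3cn(-c4ccc(C#N)cc4)nn3)c3cc(CC=C(C)C)c(OC)cc3O2)cc1` gives 42%
compound 2 `COc1ccc([C@@H]2C/C(=N/O)c3cc(CC=C(C)C)c(OC)cc3O2)cc1` gives 66%
compound 3 `CCCCOc1ccc([C@@H]2CC(=O)c3cc(CC=C(C)C)c(OC)cc3O2)cc1` gives 37%

All three values come from a functional assay on A549 cells (Homo sapiens) for inhibition, read by sulforhodamine B assay, with a stated time of 48 h, tested at 50 uM (on this read-out higher numbers stand for more inhibition of growth at the one concentration tested and lower numbers for less inhibition of growth), and are the only data so far. Compound 1 at 42% sits within the scatter of compound 3 at 37% in this small set, while compound 2 at 66% lies higher, beyond the scatter.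

Compound 4 `COc1ccc([C@@H]2C/C(=N/OCc3cn(-c4ccc(C(N)=O)cc4)nn3)c3cc(CC=C(C)C)c(OC)cc3O2)cc1` is not yet measured. It differs from compound 1 at one place, where 4-cyanophenyl becomes 4-carbamoylphenyl: carbamoyl in place of cyano on an aromatic carbon so that carbamoyl takes the place of cyano on an aromatic carbon, para to a large group.

Going by the values given here, no pair of measured compounds differs at this place, so the data show no size for this change. In this assay the expectation is no step beyond the scatter, and it rests on compound 1 with its 42% as the only reference that shares everything else. The estimated step is a number 2 percentage points lower from compound 1 to compound 4 (within the scatter) and no direction is clearly favoured. For compound 4 the expected value is 40% within an estimated range of 24% to 56% on this read-out.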

Compound 4, percent growth inhibition at one concentration: 100%
For compound 4 the middle estimate is 60 percentage points below the measured one; measured number outside the range, above it.
By their numbers in this assay, from the lowest: compounds 3 and 1 (each within the scatter of the next); then compound 2; then compound 4.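

In this assay, the change from 4-cyanophenyl to 4-carbamoylphenyl reads a number 58 percentage points higher from compound 1 to compound 4 (beyond the scatter). This aromatic carbon, para to a large group, therefore has a strong bearing on the read-out: with the rest of the structure held constant, replacing cyano (2 heavy atoms, 0 hydrogen-bond donors) with carbamoyl (3 heavy atoms, 1 hydrogen-bond donor) moves the number well beyond the scatter, so a change this small cannot be treated as neutral at this place. The data shown include no measurement that accounts for the step.

Still open, going by these compounds, is whether the step is specific to carbamoyl or would also appear with a carboxylic acid, a methylcarbamoyl group or an aminomethyl group on the same aromatic carbon. Compound 4 gives 100% at a single concentration in a single cell line, so the data shown leave open how the compound behaves at lower concentrations, and whether the same exchange would have a comparable effect with a different group in place of the butoxy, methoxy or prenyl-type substituents on the shared core.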